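Working notes: trifluoromethyl in place of methoxycarbonyl

The source may report more compounds than this note shows. Statements on the series, on what has been measured and on what is new or still open speak of the compounds shown alone.

Measured compounds:
- compound 1 `C=CC(=O)N1C(=O)CC(c2ccc([N+](=O)[O-])cc2)Sc2ccccc21`: in a functional assay on HL-60 cells (Homo sapiens) for cytotoxicity, read by CCK-8 assay, with a stated time of 24 h (on this read-out higher numbers stand for weaker inhibition and lower numbers for stronger inhibition), compound 1 gives 107000 nM
- compound 2 `C=CC(=O)N1C(=O)CC(c2ccc(OC)cc2)Sc2ccccc21`: in this assay compound 2 gives 92100 nM
- compound 3 `C=CC(=O)N1C(=O)CC(c2ccc(C(=O)OC)cc2)Sc2ccccc21`: in this assay compound 3 gives 102000 nM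

Compound 3 sits among the other two: a 1.0-fold lower number from compound 1 to compound 3 (0.02 log units; within the scatter) and a 1.1-fold higher number from compound 2 to compound 3 (0.04 log units; within the scatter), so all three numbers lie together. Compound 4 `C=CC(=O)N1C(=O)CC(c2ccc(C(F)(F)F)cc2)Sc2ccccc21` differs from compound 3 by trifluoromethyl in place of methoxycarbonyl on an aromatic carbon. Among the compounds with values here, the steps that bear on this are the earlier exchanges at the same aromatic carbon, a 1.2-fold lower number from compound 1 to compound 2 (0.07 log units; within the scatter), a 1.0-fold lower number from compound 1 to compound 3 (0.02 log units; within the scatter) and a 1.1-fold higher number from compound 2 to compound 3 (0.04 log units; within the scatter), none of them beyond the scatter. No step beyond the scatter is therefore expected in this assay for compound 4, and its number is estimated at 100000 nM (range 50000 nM to 200000 nM), an expected 1.0-fold lower number from compound 3 to compound 4 (0.01 log units; within the scatter).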

Compound 4, half-maximal inhibitory concentration: 106000 nM
Compound 4: middle estimate off by 1.1-fold (0.03 log units), on the low side; the measured number falls inside the stated range.
By their numbers in this assay, from the lowest: compounds 2, 3, 4 and 1 (each within the scatter of the next).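

Trifluoromethyl, with 0 hydrogen-bond acceptors, is a fourth group at this aromatic carbon in this assay that brings no step beyond the scatter: against methoxycarbonyl (a 1.0-fold higher number from compound 3 to compound 4 (0.02 log units; within the scatter)), against methoxy (a 1.2-fold higher number from compound 2 to compound 4 (0.06 log units; within the scatter)) and against nitro (a 1.0-fold lower number from compound 1 to compound 4 (0.00 log units; within the scatter)). All four compounds therefore remain within the scatter of one another at this position. No measurement at hand accounts for this.

Going by these compounds, whether an amine, a carboxylic acid or a longer chain at this aromatic carbon would give a step beyond the scatter remains open.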